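Removing the Methoxy Group from Compound 2

This account rests on a few compounds, and the source may have more. Where it says the series, first, only, none or still open, it means among the compounds named here.

Three compounds have numbers in a functional assay on cells (Erythrocyte, Homo sapiens) for inhibition, read by spectrophotometry and hemolysis, with a stated time of 10 min; on this read-out higher numbers stand for weaker inhibition and lower numbers for stronger inhibition. Compound 1 (`COc1cc(/C=N/NC(=O)CCCc2nc3ccccc3c(=O)[nH]2)cc(OC)c1O`) gives 524000000 nM, compound 2 (`COc1cc(/C=N/NC(=O)CCCc2nc3ccccc3c(=O)[nH]2)cc(O)c1O`) gives 277000000 nM, and compound 3 (`O=C(CCc1nc2ccccc2c(=O)[nH]1)N/N=C/c1cc(O)c(O)c(O)c1`) gives 203000000 nM. Compound 2 stands within the scatter of both of the others, so these numbers place it in one narrow band and do not separate it from either neighbour. Compound 3 differs from compound 2 in more than one place, so only its value can be read against the others.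

Compound 4 (`O=C(CCCc1nc2ccccc2c(=O)[nH]1)N/N=C/c1ccc(O)c(O)c1`) is still unmeasured. It comes from compound 2 by a single change, (hydrogen in place of methoxy on an aromatic carbon), which is hydrogen in place of methoxy on an aromatic carbon.

Among the compounds with values here, one measured step bears on this, at the same methoxy group, with hydrogen in place of methyl on an oxygen on an aromatic ring: a 1.9-fold lower number from compound 1 to compound 2 (0.28 log units; within the scatter). That step removes only the methyl and not the whole group, so it is a guide rather than a direct precedent. Since it stayed within the scatter, no step beyond the scatter is expected here either. The expected step is a 1.1-fold lower number from compound 2 to compound 4 (0.04 log units; within the scatter). For compound 4 the estimate is 250000000 nM, with an expected range from 120000000 nM to 520000000 nM.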

Compound 4, half-maximal inhibitory concentration: 300000000 nM
Compound 4: the middle estimate sits 1.2-fold (0.08 log units) below what was measured; low and high end bracket the measured number.
By their numbers in this assay, from the lowest: compounds 3, 2, 4 and 1 (each within the scatter of the next, the first and the last beyond it).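

In this assay the removal of the whole methoxy group leaves the number within the scatter, with a 1.1-fold higher number from compound 2 to compound 4 (0.03 log units; within the scatter). The earlier compounds shown here spoke only to the loss of the methyl at this position, through a 1.9-fold lower number from compound 1 to compound 2 (0.28 log units; within the scatter), whereas this step shows that losing all 2 heavy atoms of the methoxy group and its 1 hydrogen-bond acceptor from this aromatic carbon, ortho to a hydroxy group and meta to a hydroxy group, also gives no change beyond the scatter. Nothing shown offers an explanation for this result.

The compounds shown leave open whether a different group on this aromatic carbon, such as an amine, a carboxylic acid or a fluorine atom, would give a step beyond the scatter. They also leave open whether a longer chain between the shared core and the hydrazone-linked ring would leave the same replacement of methoxy by hydrogen within the scatter.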